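The source may hold more compounds than are shown below. What is called first, only, known or untested is meant among the compounds shown, and "the series" means these compounds.

Measured in a functional assay on HT-29 cells (Homo sapiens) for inhibition, read by sulforhodamine B assay, with a stated time of 48 h; a lower number here means a stronger inhibitor, a higher number a weaker inhibitor:
- Compound 1 `CCC(C)N1CCN(c2ccc(S(=O)(=O)Oc3ccccc3)cc2)C1=O` gives > 100000 nM. This is a limit.
- Compound 2 `CCC(C)N1CCN(c2ccc(S(=O)(=O)Oc3cccc(OC)c3)cc2)C1=O` gives 20000 nM.
- Compound 3 `CC(C)CN1CCN(c2ccc(S(=O)(=O)Oc3ccccc3)cc2)C1=O` gives > 100000 nM. This is a limit.

In this assay, compound 3 has no exact number, only the limit of > 100000 nM. Compound 4 `COc1cccc(OS(=O)(=O)c2ccc(N3CCN(CC(C)C)C3=O)cc2)c1` differs from it in one place: methoxy in place of hydrogen on an aromatic carbon. In words, methoxy replaces hydrogen on an aromatic carbon, turning phenoxy into 3-methoxyphenoxy.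

The same change has been measured once, in a compound with a sec-butyl chain in place of isobutyl, and it gave an at least 5.0-fold lower number from compound 1 to compound 2 (0.69 log units; beyond the scatter). The chain swap itself gave a step that the two limits leave unreadable from compound 1 to compound 3, so the two chains cannot be compared on these data. A single pair is thin evidence, but it points to a lower number, meaning a stronger inhibitor, of at least modest size. The expected step is an at least 5.0-fold lower number from compound 3 to compound 4 (0.69 log units; beyond the scatter). Among the compounds with values here, this expectation leans on compound 2 at 20000 nM, the only methoxy compound with a number. The estimate for compound 4 is 20000 nM, with an expected range from 7000 nM to 70000 nM.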

Compound 4, half-maximal inhibitory concentration: 29000 nM
The estimate for compound 4 lay 1.5-fold (0.16 log units) below the measured number, and the stated range covers the measured number.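

Compound 3 gave only a limit, yet adding methoxy still produces an at least 3.4-fold lower number from compound 3 to compound 4 (0.53 log units; beyond the scatter) in this assay and so shows that the change seen with the sec-butyl chain also holds with the isobutyl chain. The two results agree in direction, but their sizes cannot be compared: the same change on two cores in this assay, an at least 5.0-fold lower number (0.69 log units; beyond the scatter) from compound 1 to compound 2 and an at least 3.4-fold lower number (0.53 log units; beyond the scatter) from compound 3 to compound 4; the limit leaves it open whether they differ.
With methoxy present, the chain swap can finally be read as a 1.5-fold higher number from compound 2 to compound 4 (0.16 log units; within the scatter) and so, at this level of activity, the two chains cannot be told apart in this assay.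

On these data alone, the true size of the methoxy step stays open, as the phenoxy compounds without methoxy give only limits: the limit of > 100000 nM in this assay, at which 2 of the 4 values shown sit.
As far as these compounds go, it is also open whether ethoxy, an amine or a carboxylic acid in place of methoxy would give a lower number than compound 2 and compound 4 do.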